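This account rests on a few compounds, and the source may have more. Where it says the series, first, only, none or still open, it means among the compounds named here.

Compound 1, `CCCCCCn1nc(-c2ccccc2)c(-c2ccccc2)cc1=O`, gives 57000 nM in an assay on microsomes from liver for inhibition of sterol O-acyltransferase 1 (Rattus norvegicus); a higher number here means a weaker inhibitor, a lower number a stronger inhibitor. Compound 2, `CCCCCCCn1nc(-c2ccccc2)c(-c2ccccc2)cc1=O`, gives 86000 nM in this assay. Compound 3, `CCCCCC[S+]([O-])c1cc(-c2ccccc2)c(-c2ccccc2)nn1`, gives 75000 nM in this assay.

Compound 1 and compound 2 differ by methyl in place of hydrogen on a saturated chain carbon, six bonds along the chain from an aromatic nitrogen, and that change made a 1.5-fold higher number from compound 1 to compound 2 (0.18 log units; within the scatter). Compound 4, `CCCCCCC[S+]([O-])c1cc(-c2ccccc2)c(-c2ccccc2)nn1`, has not yet been measured; it differs from compound 3 by methyl in place of hydrogen on a saturated chain carbon, six bonds along the chain from a sulfur. Among the measured compounds shown here, this is the same kind of change as the one from compound 1 to compound 2, though the place differs: in the first pair the saturated chain carbon lies six bonds along the chain from an aromatic nitrogen, in the second six bonds along the chain from a sulfur. The difference between the core of compound 1 and the core of compound 3 is not broken down here; their values in this assay lie close together. Resting on a 1.5-fold higher number from compound 1 to compound 2 (0.18 log units; within the scatter), a step within the scatter, compound 4 is expected to show a 1.3-fold higher number from compound 3 to compound 4 (0.12 log units; within the scatter). Compound 4 is therefore estimated at 100000 nM, between 45000 nM and 220000 nM.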

Compound 4, half-maximal inhibitory concentration: 77000 nM
Beside the measured number, compound 4's estimate is 1.3-fold (0.11 log units) above it; low and high end bracket the measured number.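

The step on the core of compound 3 reads a 1.0-fold higher number from compound 3 to compound 4 (0.01 log units; within the scatter) in this assay. Set beside the earlier step, the same change gives matching results on the two cores: the same change on two cores in this assay, a 1.5-fold higher number (0.18 log units; within the scatter) from compound 1 to compound 2 and a 1.0-fold higher number (0.01 log units; within the scatter) from compound 3 to compound 4, 1.5-fold (0.17 log units) apart, within the scatter of two such steps. This shows that neither core responds to the added methyl beyond the scatter, but with both steps this small it does not show that a real effect carries from one core to the other, only that no effect is seen on either.

The compounds shown leave open whether a much longer chain, or an amine or a carboxylic acid in place of the chain, would give a step beyond the scatter. They also leave open whether such a step would then carry between the two cores.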